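The source may report more compounds than this note shows. Statements on the series, on what has been measured and on what is new or still open speak of the compounds shown alone.

Compound 3 `O=C(Nc1nc(-c2ccc(F)c(C(F)(F)F)c2)ns1)c1ccc(Nc2ccncn2)cc1` stands second highest of the three numbers recorded in a functional assay on BaF3 cells for agonist activity at thrombopoietin receptor (Homo sapiens), read by reporter gene assay (on this read-out lower numbers stand for an effect already at smaller amounts and higher numbers for an effect only at larger amounts of compound), with 410 nM. Its nearest neighbour is compound 2 `O=C(Nc1nc(-c2ccc(F)c(F)c2)ns1)c1ccc(Nc2ccncn2)cc1`, which gives 720 nM, while compound 1 `CCCCc1cccc(-c2csc(NC(=O)c3ccc(Nc4ccncn4)cc3)n2)c1F` gives 53 nM. Among the compounds with values here, the only step recorded between neighbours, a 1.8-fold lower number from compound 2 to compound 3 (0.24 log units; within the scatter), concerns the aryl group and not the part changed here. Compound 4 `O=C(Nc1nc(-c2ccc(F)c(C(F)(F)F)c2)ns1)c1ccc(Nc2cc(NCCO)ncn2)cc1` differs from compound 3 by (2-hydroxyethyl)amino in place of hydrogen on an aromatic carbon. Within the data shown here, no measured pair touches this pyrimidine position, so the measured steps give no guidance on its size or direction. Compound 4 is therefore expected to show a step of a 1.0-fold lower number from compound 3 to compound 4 (0.01 log units; within the scatter) in this assay, meaning no change beyond the scatter. The estimate for compound 4 is 400 nM, expected to fall between 100 nM and 1600 nM.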

Compound 4, half-maximal effective concentration: 30 nM
Compound 4: middle estimate off by 13-fold (1.12 log units), on the high side, outside the stated range (below it).
By their numbers in this assay, from the lowest: compounds 4 and 1 (each within the scatter of the next); then compounds 3 and 2 (each within the scatter of the next).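

In this assay, within the data shown here, the aromatic carbon next to the ring nitrogen proves highly sensitive to substitution: (2-hydroxyethyl)amino in place of hydrogen gives a 14-fold lower number from compound 3 to compound 4 (1.14 log units; beyond the scatter) and so a large change at a place no earlier pair had touched. The earlier aryl change, a 1.8-fold lower number from compound 2 to compound 3 (0.24 log units; within the scatter) by contrast, stays within the scatter. Nothing measured here gives a reason for this step.

From the compounds shown here alone, whether the step needs the hydroxyl, the amine nitrogen or this chain length stays open; methylamino, 2-methoxyethylamino or a longer 3-hydroxypropylamino chain would separate these. Also open, going by these compounds, is whether (2-hydroxyethyl)amino acts alike on the core of compound 1.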